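The source may report more compounds than this note shows. Statements on the series, on what has been measured and on what is new or still open speak of the compounds shown alone.

Measured so far in a functional assay on MCF7 cells (Homo sapiens) for antiproliferative activity, read by MTT assay, with a stated time of 72 h (a higher number here means a weaker inhibitor, a lower number a stronger inhibitor), are two compounds:

- Compound 1 `COc1cc(-n2cnc3ccc(-c4ccc(C(F)(F)F)cc4)cc32)cc(OC)c1OC` gives 760 nM
- Compound 2 `COc1cc(-n2cnc3ccc(-c4cccc(N)c4)cc32)cc(OC)c1OC` gives 180 nM

Compound 2 has the lower of these two numbers, which makes it the stronger inhibitor of the pair. Compound 3 `COc1cc(-n2cnc3ccc(-c4ccc(O)cc4)cc32)cc(OC)c1OC` has not yet been measured. It carries 4-hydroxyphenyl in place of 3-aminophenyl on an aromatic carbon and is otherwise unchanged.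

Within the data shown here, only one measured step bears on this swap: a 4.2-fold lower number from compound 1 to compound 2 (0.63 log units; beyond the scatter) in a modest move at the same place. Among the measured compounds shown here, no measured compound carries 4-hydroxyphenyl, so that step gives only a rough scale. In this assay the expected change is small, toward a higher number, and within the scatter: the estimate is a 1.4-fold higher number from compound 2 to compound 3 (0.14 log units; within the scatter) and no more. Compound 3 is estimated at 250 nM with an expected range from 70 nM to 900 nM as its likely span.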

Compound 3, half-maximal inhibitory concentration: 4160 nM
The estimate for compound 3 lay 17-fold (1.22 log units) below the measured number, outside the stated range (above it).
By their numbers in this assay, from the lowest: compound 2; then compound 1; then compound 3.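

In this assay, this position does not treat similar-sized groups alike: 4-hydroxyphenyl in place of 3-aminophenyl gives a 23-fold higher number from compound 2 to compound 3 (1.36 log units; beyond the scatter), the first large step seen here. The two groups match in heavy atoms, hydrogen-bond donors and acceptors, and net charge, so those counts alone do not track the result. Hydroxy in place of trifluoromethyl also raises the number, giving a 5.5-fold higher number from compound 1 to compound 3 (0.74 log units; beyond the scatter), which leaves compound 3 as the weakest of the three.

Nothing shown here gives a measured reason for these differences. Between compound 2 and compound 3, both the group and its numbered place on the phenyl ring change, so the effect of each remains open; 3-hydroxyphenyl or 4-aminophenyl on the same core would help separate them.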